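Changing the Aryl Group on the Ring Nitrogen

The compounds below may be only part of what the source reports. "The series", "measured", "known", "first", "only" and "open" are said of these compounds alone.

Compound 1 `COc1ccc(OC)c(N2C(=O)CSC2c2cccc(C(=O)NCCCCc3ccccc3)c2)c1` carries a 2,5-dimethoxyphenyl group on the ring nitrogen of the shared core. In a functional assay on 143B cells (Homo sapiens) for inhibition, read by CCK-8 assay, with a stated time of 72 h, tested at 1 uM (on this read-out higher numbers stand for more inhibition at the one concentration tested (going by the name of the read-out) and lower numbers for less inhibition), compound 1 gives 2%, the lowest of the three measured compounds. Compound 2 `COc1cc(F)ccc1N1C(=O)CSC1c1cccc(C(=O)NCCCCc2ccccc2)c1` gives 63%, and compound 3 `COc1cccc(OC)c1N1C(=O)CSC1c1cccc(C(=O)NCCCCc2ccccc2)c1` gives 31%. Both measured changes at this position move the read-out beyond the scatter: a number 61 percentage points higher from compound 1 to compound 2 (beyond the scatter), and a number 29 percentage points higher from compound 1 to compound 3 (beyond the scatter). Compound 4 `CC(F)(F)c1cccc(N2C(=O)CSC2c2cccc(C(=O)NCCCCc3ccccc3)c2)c1` differs from compound 1 in the same place: a group of 10 heavy atoms (8 carbon, 2 fluorine; one six-membered aromatic ring of carbon only) in place of a group of 10 heavy atoms (8 carbon, 2 oxygen; one six-membered aromatic ring of carbon only), on an amide-type nitrogen in a ring. The two measured steps show that this position is sensitive and that leaving compound 1 raised inhibition in each case, but neither step removes every methoxy group, so the size of this change is uncertain. Compound 4 is therefore expected to show a number 28 percentage points higher from compound 1 to compound 4 (beyond the scatter), an estimate of 30% with a range from 5% to 60%.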

Compound 4, a percentage reported as inhibition, at one concentration (the size of the read-out at that concentration, not a potency): 1%
Compound 4: the middle estimate sits 29 percentage points above what was measured; the measured number lies below the stated range.
By their numbers in this assay, from the lowest: compounds 4 and 1 (each within the scatter of the next); then compound 3; then compound 2.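

Leaving the 2,5-dimethoxyphenyl group does not always raise inhibition at this position, as both earlier steps had suggested: in this assay, the step is a number 1 percentage points lower from compound 1 to compound 4 (within the scatter). A ring carrying fluorine and no oxygen can therefore read like compound 1. It also falls well short of the other two aryl groups, with a number 30 percentage points lower from compound 3 to compound 4 (beyond the scatter) and a number 62 percentage points lower from compound 2 to compound 4 (beyond the scatter).

Nothing available explains why these aryl groups differ. Open too, from the compounds shown here alone, is how an unsubstituted phenyl or a pyridine ring would read here.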